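Aryl swap on the carbonyl in a sulfonamide amide series

A few compounds are considered here, and "the series" means these few. Any claim that something is new, unique, unknown or untested is made for them only; others in the source may bear on it.

Measured so far in an assay on MDA-MB-231 cells for binding affinity to C-X-C chemokine receptor type 4 (Homo sapiens), read by immunofluorescence and microscopy, with stated times of 10 min and 30 min; a lower number here means that less compound is needed, a higher number that more compound is needed for the effect:
compound 1 `Cc1ccc(S(=O)(=O)NCc2ccc(CNC(=O)c3c(Cl)cc(Cl)cc3Cl)cc2)cc1` gives 10 nM
compound 2 `O=C(NCc1ccc(CNS(=O)(=O)c2ccccc2)cc1)c1c(Cl)cc(Cl)cc1Cl` gives 10 nM
compound 3 `Cc1cccc(C(=O)NCc2ccc(CNS(=O)(=O)c3ccccc3)cc2)c1` gives 1000 nM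

Compound 1 stands level with compound 2 at the digits shown, and the two together give the lowest numbers of the three, with compound 3 far above them. The step of no change at the digits printed from compound 1 to compound 2 (within the scatter) shows that the change on the sulfonyl aryl ring stays within the scatter. The step of a 100-fold higher number from compound 2 to compound 3 (2.00 log units; beyond the scatter) is the one that carries weight here: exchanging the aryl group on the carbonyl carbon brings a large loss.

Compound 4 `COc1cccc(C(=O)NCc2ccc(CNS(=O)(=O)c3ccc(C)cc3)cc2)c1` is not yet measured. Against compound 1 the difference is 3-methoxyphenyl in place of 2,4,6-trichlorophenyl on a carbonyl carbon. Within the data shown here, this is the same kind of exchange as the one behind a 100-fold higher number from compound 2 to compound 3 (2.00 log units; beyond the scatter), only with a different entering ring, and no measured pair speaks to the methoxy-for-methyl distinction, so the expectation rests on that one step alone. A large rise is expected, a 100-fold higher number from compound 1 to compound 4 (2.00 log units; beyond the scatter). Compound 4 is therefore estimated at 1000 nM, with an expected range from 300 nM to 3000 nM.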

Compound 4, effective concentration (reported as EC, without a stated level of effect): 10 nM
Beside the measured number, compound 4's estimate is 100-fold (2.00 log units) above it; measured number outside the range, below it.
By their numbers in this assay, from the lowest: compounds 1, 2 and 4 (each within the scatter of the next); then compound 3.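

In this assay the exchange of 2,4,6-trichlorophenyl for 3-methoxyphenyl on a carbonyl carbon gives no change at the digits printed from compound 1 to compound 4 (within the scatter) and so shows that a low number at this position does not depend on the 2,4,6-trichlorophenyl group. The large loss in a 100-fold higher number from compound 2 to compound 3 (2.00 log units; beyond the scatter) therefore cannot be read as a general result of removing that group, and compound 4 goes against any such rule. Nothing at hand bears on the reason for this result.

Among these compounds, compounds 3 and 4 differ in two places, so no step separates the 3-methoxyphenyl ring from the 3-methylphenyl ring on the carbonyl carbon. From the compounds shown here alone, whether 3-aminophenyl, 3-carboxyphenyl or 3-ethoxyphenyl on the same carbonyl carbon would stay level with compound 1 remains open.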